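The source may report more compounds than this note shows. Statements on the series, on what has been measured and on what is new or still open speak of the compounds shown alone.

In an ADME assay on SK-OV-3 cells (Homo sapiens) for cytotoxicity (a lower number here means that less compound is needed, a higher number that more compound is needed for the effect), compound 2 `O=C1NC[C@@H](c2c[nH]c3ccccc23)N=C1c1c[nH]c2ccccc12` gives 12.6 ug/mL. Compound 1 `O=C1NC[C@@H](c2c[nH]c3cc(Br)ccc23)N=C1c1c[nH]c2ccccc12` carries bromo in place of hydrogen on an aromatic carbon, and in this assay compound 1 gives 8.5 ug/mL; the resulting step of a 1.5-fold lower number from compound 2 to compound 1 (0.17 log units; within the scatter) is a small one. Compound 3 `O=C(C1=NC(c2c[nH]c3ccccc23)CN1)c1c[nH]c2cc(Br)ccc12` rests on a different core; how the core of compound 3 differs from the core of compound 2 is not broken down here. For compound 3 this assay reports no number but only a limit, > 30 ug/mL, which is the limit of > 30 ug/mL in this assay, at which 1 of the 3 values shown sits.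

Compound 4 `O=C(C1=NC(c2c[nH]c3cc(Br)ccc23)CN1)c1c[nH]c2cc(Br)ccc12` has not yet been measured in this assay. It differs from compound 3 by bromo in place of hydrogen on an aromatic carbon, the same change that separates compound 2 from compound 1, with the place described in the same words in both pairs; the change appears in two pairs among the compounds here. Because the earlier step of a 1.5-fold lower number from compound 2 to compound 1 (0.17 log units; within the scatter) stayed within the scatter, the step that the limit leaves unreadable from compound 3 to compound 4 is expected to be of a similarly small size. Since this assay gave only a limit for compound 3, the reading for compound 4 is expected to sit near or beyond that limit as well, and quite possibly to come back as a limit again. On that basis compound 4 is estimated at 40 ug/mL, with the expected range running from 15 ug/mL to 120 ug/mL.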

Compound 4, concentration for half-maximal effect: 4.81 ug/mL
Beside the measured number, compound 4's estimate is 8.3-fold (0.92 log units) above it; the measured number lies below the stated range.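

In this assay, bromo in place of hydrogen on an aromatic carbon gives an at least 6.2-fold lower number from compound 3 to compound 4 (0.79 log units; beyond the scatter), so on the core of compound 3 the change comes with a clear drop in the number needed for the effect. Set beside the same change on the core of compound 2, this shows that the size of the step did not carry over from one core to the other: the same change on two cores in this assay, a 1.5-fold lower number (0.17 log units; within the scatter) from compound 2 to compound 1 and an at least 6.2-fold lower number (0.79 log units; beyond the scatter) from compound 3 to compound 4, at least 4.2-fold (0.62 log units) apart, beyond the scatter of two such steps

What this does not show is the exact size of the new step, or any rule for cores beyond these two pairs, and it gives no reason for the gap, as the reading of compound 3 is a limit and not a number: the limit of > 30 ug/mL in this assay, at which 1 of the 4 values shown sits.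

The compounds shown leave open whether chloro, methyl or an amine on the same aromatic carbon would also give steps that differ between the two cores. They also leave open how far the gap between the two steps would reach if compound 3 had an exact reading, and whether a third core would follow the core of compound 2 or that of compound 3.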